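The source may hold more compounds than are shown below. What is called first, only, known or untested is meant among the compounds shown, and "the series" means these compounds.

The series shares the core seen in compound 1 `CC(C)C(C(N)=O)c1ccc(Cl)cc1`, where the amide nitrogen carries no substituent. In a functional assay on CHO cells for agonist activity at Free fatty acid receptor 2 (Homo sapiens), read by cAMP accumulation (a lower number here means a smaller maximal response, a higher number a larger maximal response), compound 1 reaches only the assay limit of < 30%. Compound 2 `CC(C)[C@H](C(=O)NC(C)(C)C)c1ccc(Cl)cc1` carries a tert-butyl group on the amide-type nitrogen. In this assay compound 2 likewise reaches only the limit of < 30%, so no number is known for it. Compound 3 `CC(C)[C@H](C(=O)Nc1nnc(C(F)(F)F)s1)c1ccc(Cl)cc1` puts a ring-bearing group on the amide-type nitrogen instead, and in this assay compound 3 gives 115%. Two of the three values thus sit at the limit of < 30% in this assay, at which 2 of the 3 values shown sit, and only compound 3 shows a large maximal response.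

Compound 4 `Cc1csc(NC(=O)[C@H](c2ccc(Cl)cc2)C(C)C)n1` differs from compound 2 in one place: 4-methyl-1,3-thiazol-2-yl in place of tert-butyl on an amide-type nitrogen. Because compound 3 gives 115% when a five-membered aromatic ring with 2 hetero atoms sits on the amide-type nitrogen, a large rise in this assay is expected from compound 2 to compound 4. For compound 4 an efficacy of about 90% is expected, within 45% to 125%. That expectation amounts to a rise of a number at least 60 percentage points higher from compound 2 to compound 4 (beyond the scatter) in this assay, well beyond the usual scatter.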

Compound 4, largest response reached (reported as efficacy), in percent of the reference or control that the assay uses: 87%
Compound 4: middle estimate off by 3 percentage points, on the high side; low and high end bracket the measured number.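

Going by these compounds alone, this is the first measured step at this position, and it shows that changing only the group on the amide-type nitrogen can decide whether a large maximal response appears: 4-methyl-1,3-thiazol-2-yl in place of tert-butyl gives a number at least 57 percentage points higher from compound 2 to compound 4 (beyond the scatter) in this assay. Within the data shown here, it also shows that a large response does not depend on the one group in compound 3, since a different five-membered aromatic ring in compound 4 gives 87%. The size of the step is only a lower bound, because compound 2 has a limit rather than a number: the limit of < 30% in this assay, at which 2 of the 4 values shown sit.

Going by these compounds, whether the hetero atoms of the ring are needed stays open, as a plain phenyl ring on this nitrogen would test that. The compounds shown also leave open what the methyl group on the ring contributes, and how an amine or a carboxylic acid on the ring would behave.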